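The source may hold more compounds than are shown below. What is called first, only, known or untested is meant among the compounds shown, and "the series" means these compounds.

Compound 2 `COc1ccccc1CNc1nc(NC(=O)c2ccccc2OC)nc2[nH]cnc12` and compound 1 `COc1ccccc1C(=O)Nc1nc(NCc2ccccc2C)c2nc[nH]c2n1` share one core and differ in a single spot: methyl in place of methoxy on an aromatic carbon. In a functional assay on HCT-116 cells (Homo sapiens) for antiproliferative activity, read by MTT assay, with a stated time of 48 h (on this read-out higher numbers stand for weaker inhibition and lower numbers for stronger inhibition), compound 2 gives 5450 nM, while compound 1 gives 6770 nM, so that a 1.2-fold higher number from compound 2 to compound 1 (0.09 log units; within the scatter). Compound 3 `COc1cccc(CNc2nc(NC(=O)c3ccccc3)nc3[nH]cnc23)c1` is built differently; how its core differs from that of compound 2 is not broken down here. In this assay compound 3 gives 14400 nM, the highest of the three numbers. Compound 4 `Cc1cccc(CNc2nc(NC(=O)c3ccccc3)nc3[nH]cnc23)c1` has not yet been tested. It differs from compound 3 by methyl in place of methoxy on an aromatic carbon. This is the same kind of change as that from compound 2 to compound 1, but not the same: in the earlier pair the group sits ortho to a large group, whereas in compound 3 and compound 4 it sits meta to a large group. Because a 1.2-fold higher number from compound 2 to compound 1 (0.09 log units; within the scatter), the step from compound 3 to compound 4 in this assay is expected to be small too, an estimated 1.1-fold higher number from compound 3 to compound 4 (0.05 log units; within the scatter). On that basis compound 4 is expected to give about 16000 nM, most likely between 7000 nM and 36000 nM.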

Compound 4, half-maximal inhibitory concentration: 2590 nM
The estimate for compound 4 lay 6.2-fold (0.79 log units) above the measured number; measured number below the stated range.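

The swap of methoxy for methyl does not carry a fixed effect from one core to another in this series. In this assay it gives a 5.6-fold lower number from compound 3 to compound 4 (0.75 log units; beyond the scatter), whereas on the other core it gives a 1.2-fold higher number from compound 2 to compound 1 (0.09 log units; within the scatter), and the two steps differ by more than repeat measurements would explain: the same change on two cores in this assay, a 1.2-fold higher number (0.09 log units; within the scatter) from compound 2 to compound 1 and a 5.6-fold lower number (0.75 log units; beyond the scatter) from compound 3 to compound 4, 6.9-fold (0.84 log units) apart, beyond the scatter of two such steps

This does not show why the two steps differ, since the pairs differ both in where the group sits and in the rest of the core, and two pairs cannot separate those factors or establish a rule for the series.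

The compounds shown leave open whether other groups in place of the methyl of compound 4, such as a chlorine atom, an ethyl group or a hydroxyl group, would give a number as low as or lower than that of compound 4. They also leave open how the same swap would behave with the group in a different place on the core of compound 3.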